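Nitro on the phenyl of compound 3

The compounds below may be only part of what the source reports. "The series", "measured", "known", "first", "only" and "open" are said of these compounds alone.

Compound 3 `CCCSc1nc(N/N=C/c2ccccc2)c2nnn(Cc3ccccc3)c2n1` carries an unsubstituted phenyl on the carbon with a double bond to nitrogen. In a functional assay on ECa-109 cells (Homo sapiens) for antiproliferative activity, read by MTT assay, with a stated time of 72 h (a higher number here means a weaker inhibitor, a lower number a stronger inhibitor), compound 3 sits at a limit, > 64000 nM, not at a number. Compound 1 `CCCSc1nc(N/N=C/c2cccc(Cl)c2)c2nnn(Cc3ccccc3)c2n1` likewise sits at a limit in this assay, > 64000 nM. For the measured compounds named here, compound 2 `CCCSc1nc(N/N=C/c2c(O)ccc3ccccc23)c2nnn(Cc3ccccc3)c2n1` is the only member with a number, 9290 nM, and the step of an at least 6.8-fold higher number from compound 2 to compound 3 (0.83 log units; beyond the scatter) is therefore readable only as a bound. The step that the two limits leave unreadable from compound 1 to compound 3 is the one that bears most directly on a substituent on the phenyl ring, yet it cannot be sized because of the limit of > 64000 nM in this assay, at which 2 of the 3 values shown sit.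

Compound 4 `CCCSc1nc(N/N=C/c2ccc([N+](=O)[O-])cc2)c2nnn(Cc3ccccc3)c2n1` differs from compound 3 by nitro in place of hydrogen on an aromatic carbon. Only compound 1 and compound 3 show what a single substituent on that ring does, and both rest at the same limit; nothing shown separates them. The expectation for compound 4 is therefore a step of a number no higher from compound 3 to compound 4 (the limit leaves the size open) that does not leave the limit region, with a real chance that this assay again reports only a bound. The estimate for compound 4 in this assay is 64000 nM, expected to fall between 15000 nM and 250000 nM.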

Compound 4, half-maximal inhibitory concentration: 6640 nM
The estimate for compound 4 lay 9.6-fold (0.98 log units) above the measured number, and the stated range ends above it.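

In this assay, nitro on the phenyl ring gives the first readable effect of a single substituent on that ring: an at least 9.6-fold lower number from compound 3 to compound 4 (0.98 log units; beyond the scatter). The change of aryl group gives a similar bound, an at least 9.6-fold lower number from compound 1 to compound 4 (0.98 log units; beyond the scatter), so 4-nitrophenyl clears the limit region where the 3-chlorophenyl of compound 1 does not. The hydroxynaphthyl group is also not required to leave that region, since the remaining comparison gives a 1.4-fold lower number from compound 2 to compound 4 (0.15 log units; within the scatter), and the simpler 4-nitrophenyl thus matches the 2-hydroxynaphthalen-1-yl group of compound 2 in this read-out.

Going by these compounds, it remains open whether this gain is specific to nitro or would also appear with chloro, an amine or a carboxylic acid on the same aromatic carbon, and whether moving nitro elsewhere on the ring would keep it. The true sizes of the steps from the two compounds without a number also remain unknown, because each of those steps starts from a limit and can be given only as a bound: the limit of > 64000 nM in this assay, at which 2 of the 4 values shown sit.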